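An isopropyl returns to compound 3

The source may hold more compounds than are shown below. What is called first, only, known or untested is meant among the compounds shown, and "the series" means these compounds.

Measured compounds:
compound 1, `Cc1c(OCCCCOc2ccc(F)c(C(=O)O)c2)ccc(C(=O)CC(C)(C)C)c1O`, 102%
compound 2, `Cc1c(OCCCCOc2ccc(F)c(C(=O)O)c2)ccc(C(=O)CC(C)C)c1C`, 13.8%
compound 3, `CC(=O)c1ccc(OCCCCOc2ccc(F)c(C(=O)O)c2)c(C)c1O`, 16.8%

In an assay on HEK293 cells for positive allosteric modulation of metabotropic glutamate receptor 3 (Rattus norvegicus), read by thallium flux, with a stated time of 2.5 min (on this read-out higher numbers stand for larger maximal responses and lower numbers for smaller maximal responses), compound 1 gives 102%, compound 2 gives 13.8% and compound 3 gives 16.8%. Compound 3 is second highest of the three, within the scatter of compound 2 and far below compound 1.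

Compound 4, `Cc1c(OCCCCOc2ccc(F)c(C(=O)O)c2)ccc(C(=O)CC(C)C)c1O`, differs from compound 3 by isopropyl in place of hydrogen on a saturated chain carbon bound to a carbonyl carbon. For the measured compounds named here, one measured step bears on this place: a number 85.2 percentage points lower from compound 1 to compound 3 (beyond the scatter), where a tert-butyl was removed. Compound 4 puts a branched group back there, so a rise in this assay is expected, though compound 2, which also carries an isopropyl at this place, stays low. The estimate for compound 4 is 55%, between 12% and 100%, an expected step of a number 38.2 percentage points higher from compound 3 to compound 4 (beyond the scatter).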

Compound 4, largest response reached (reported as percent of maximum), in percent of the reference or control that the assay uses: 81.7%
Estimate against measurement, compound 4: 26.7 percentage points below; low and high end bracket the measured number.
By their numbers in this assay, from the lowest: compounds 2 and 3 (each within the scatter of the next); then compound 4; then compound 1.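

In this assay, isopropyl on the saturated chain carbon bound to a carbonyl carbon is enough to bring back much of the response (a change of a number 64.9 percentage points higher from compound 3 to compound 4 (beyond the scatter)), so tert-butyl is not essential, although removing one methyl still costs something (a number 20.3 percentage points lower from compound 1 to compound 4 (beyond the scatter)). The isopropyl does not act alone: with methyl in place of hydroxy on the aromatic carbon the response stays low, and restoring the hydroxy gives a number 67.9 percentage points higher from compound 2 to compound 4 (beyond the scatter). Nothing available explains either effect. On these data alone, whether a cyclopentyl or a longer chain at the first place, or an amine at the second, would keep the response remains open.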